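The compounds below may be only part of what the source reports. "The series", "measured", "known", "first", "only" and "open" are said of these compounds alone.

In a functional assay on MCF7 cells (Homo sapiens) for antiproliferative activity, read by sulforhodamine B assay, with a stated time of 72 h; on this read-out higher numbers stand for weaker inhibition and lower numbers for stronger inhibition:
- compound 1 `COc1ncc(-c2ccc3ncnc(Nc4ccc(OCCO)cc4)c3c2)cc1NS(=O)(=O)c1ccc(F)cc1F`: 1650 nM
- compound 2 `COc1ncc(-c2ccc3ncnc(Nc4cnn(CCC(=O)O)c4)c3c2)cc1NS(C)(=O)=O`: 560 nM
- compound 3 `COC(=O)Cn1cc(Nc2ncnc3ccc(-c4cnc(OC)c(NS(=O)(=O)c5ccc(F)cc5F)c4)cc23)cn1`: 670 nM

Compound 2 sits within the scatter of compound 3 and beyond the scatter on the low side of compound 1. Compound 4 `COc1ncc(-c2ccc3ncnc(Nc4ccc(OCCO)nc4)c3c2)cc1NS(C)(=O)=O` comes from compound 2 through (6-(2-hydroxyethoxy)pyridin-3-yl in place of 1-(2-carboxyethyl)-1H-pyrazol-4-yl on a nitrogen on an aromatic ring). Among the measured compounds shown here, only one measured step bears on this: a 2.5-fold lower number from compound 1 to compound 3 (0.39 log units; beyond the scatter), with 1-((methoxycarbonyl)methyl)-1H-pyrazol-4-yl in place of 4-(2-hydroxyethoxy)phenyl. Read in reverse, it hints at a modest rise. For the measured compounds named here, the evidence is indirect, since compound 1 and compound 3 carry a different sulfonamide from compound 2, and no measured step covers the acid or the pyridine. In this assay the expected 1.4-fold higher number from compound 2 to compound 4 (0.15 log units; within the scatter) stays within the scatter, leaning towards a higher number. The estimate for compound 4 is 800 nM, with an expected range of 250 nM to 2500 nM.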

Compound 4, half-maximal inhibitory concentration: 3080 nM
Beside the measured number, compound 4's estimate is 3.9-fold (0.59 log units) below it; measured number above the stated range.
By their numbers in this assay, from the lowest: compounds 2 and 3 (each within the scatter of the next); then compounds 1 and 4 (each within the scatter of the next).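

In this assay, with the rest of compound 2 held fixed, 6-(2-hydroxyethoxy)pyridin-3-yl in place of 1-(2-carboxyethyl)-1H-pyrazol-4-yl gives a 5.5-fold higher number from compound 2 to compound 4 (0.74 log units; beyond the scatter). The number at this position therefore responds to the group's identity, even though both groups have the same counts of heavy atoms, hydrogen-bond donors and hydrogen-bond acceptors. No measurement at hand accounts for the step.

The compounds shown do not separate the ring from the chain end. A 2-hydroxyethyl chain on the pyrazole, or a carboxylic acid chain on the pyridine, would address this.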